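Swapping diethylamino for methyl on the shared core

The source may hold more compounds than are shown below. What is called first, only, known or untested is meant among the compounds shown, and "the series" means these compounds.

In a functional assay on HeLa cells (Homo sapiens) for cytotoxicity, read by MTT assay, with a stated time of 2 days (a lower number here means a stronger inhibitor, a higher number a weaker inhibitor), compound 1 (`CCN(CC)c1ccc2nc(-c3ccccc3OC(F)(F)F)[nH]c(=O)c2c1`) gives 40 nM. Two relatives keep its core and its diethylamino group but carry another group in place of trifluoromethoxy: compound 2 (`CCN(CC)c1ccc2nc(-c3ccccc3N(C)C)[nH]c(=O)c2c1`) gives 70 nM and compound 3 (`CCN(CC)c1ccc2nc(-c3ccccc3C(F)(F)F)[nH]c(=O)c2c1`) gives 100 nM. The numbers show a 1.8-fold higher number from compound 1 to compound 2 (0.24 log units; within the scatter), then a 1.4-fold higher number from compound 2 to compound 3 (0.15 log units; within the scatter), and finally a 2.5-fold higher number from compound 1 to compound 3 (0.40 log units; beyond the scatter). Compound 1 therefore cannot be told apart from compound 2, while compound 3 stands clear of compound 1 by only a modest margin.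

Compound 4 (`Cc1ccc2nc(-c3ccccc3OC(F)(F)F)[nH]c(=O)c2c1`) keeps trifluoromethoxy and instead carries methyl in place of diethylamino on an aromatic carbon. Among the compounds with values here, none of the measured steps touches this place, since all three exchange the other group, and no measured compound lacks diethylamino. As far as these compounds go, those steps therefore offer only a rough sense of scale, and the size of this change remains open. A higher number is expected, though only tentatively, since compound 1 reaches 40 nM with the diethylamino group present. The expected change is a 6.3-fold higher number from compound 1 to compound 4 (0.80 log units; beyond the scatter). For compound 4 the estimated value in this assay is 250 nM, with an expected range of 50 nM to 1200 nM.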

Compound 4, half-maximal inhibitory concentration: 850 nM
Beside the measured number, compound 4's estimate is 3.4-fold (0.53 log units) below it, within the range that was stated.
By their numbers in this assay, from the lowest: compounds 1, 2 and 3 (each within the scatter of the next, the first and the last beyond it); then compound 4.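

Within the data shown here, the earlier compounds differ only where trifluoromethoxy sits, so this is the first reading at the other place, the aromatic carbon that carries diethylamino in compound 1. In this assay the exchange of diethylamino for methyl produces a 21-fold higher number from compound 1 to compound 4 (1.33 log units; beyond the scatter) and is larger than any of the steps among compound 1, compound 2 and compound 3, so among the changes compared, this one moves the number furthest and diethylamino is the better of the two groups tried at this place. No measurement shown here explains the size of this step.

Diethylamino differs from methyl in both its nitrogen and its two ethyl chains, so this single exchange cannot say which of them accounts for the step; a primary amine, a morpholine ring or a propyl chain at this place would help to separate them. As far as these compounds go, it also remains open whether the step would be of similar size with trifluoromethyl or dimethylamino in place of trifluoromethoxy.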